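The source may report more compounds than this note shows. Statements on the series, on what has been measured and on what is new or still open speak of the compounds shown alone.

For the measured compounds named here, compound 1, `COc1cc(OC)c(/C=C/S(=O)(=O)Cc2ccc([N+](=O)[O-])cc2)c(OC)c1`, is the only member of this small set that returns an actual number in a functional assay on BT-20 cells (Homo sapiens) for antiproliferative activity, read by trypan blue exclusion (on this read-out lower numbers stand for stronger inhibition and higher numbers for weaker inhibition), where compound 1 gives 15000 nM. Compound 2, `COc1ccc(CS(=O)(=O)/C=C/c2cc(OC)ccc2OC)cc1`, does not give a number in this assay. In this assay compound 2 returns only a limit, > 20000 nM, which is the point beyond which the assay reports nothing further (the limit of > 20000 nM in this assay, at which 1 of the 2 values shown sits).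

Compound 3, `COc1ccc(CS(=O)(=O)/C=C/c2c(OC)cc(OC)cc2OC)cc1`, has not yet been measured in this assay. It is made from compound 1 by a single change: methoxy in place of nitro on an aromatic carbon. Going by the values given here, nothing among the measured compounds gives a direct step for this change, since compound 1 and compound 2 differ in more than one place, so the size of the step must be guessed. Given that compound 2, which also carries the 4-methoxyphenyl group, sits at the limit > 20000 nM, the expectation is that compound 3 is not stronger than compound 1 and may well fall beyond the limit itself. The estimated step from compound 1 to compound 3 is a 2.0-fold higher number from compound 1 to compound 3 (0.30 log units; within the scatter). Compound 3 is therefore expected to give about 30000 nM in this assay, within a range of 8000 nM to 100000 nM.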

Compound 3, half-maximal inhibitory concentration: 20 nM
The estimate for compound 3 lay 1500-fold (3.18 log units) above the measured number; measured number outside the range, below it.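

Replacing nitro with methoxy on this aromatic carbon, para to a large group, gives a 750-fold lower number from compound 1 to compound 3 (2.88 log units; beyond the scatter) in this assay. The earlier compounds shown here could not show this, as compound 1 and compound 2 differ in more than one place and so gave no direct reading of any single change; this pair shows that one exchange of a small group at this position can separate a weak compound from a strong one. The 4-methoxyphenyl group does not guarantee a strong result across the set, however, since compound 2 also carries it and returns only a limit of the assay rather than a number: the limit of > 20000 nM in this assay, at which 1 of the 3 values shown sits.

The compounds shown hold only nitro and methoxy at this position, so they leave open how an amine, a hydroxyl group or a longer chain such as ethoxy would fare there. They also cannot tell what it is about methoxy that goes with the lower number, or whether the same exchange would have as large an effect on the core of compound 2.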